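Moving a Hydroxyl Around a Shared Core

A few compounds are considered here, and "the series" means these few. Any claim that something is new, unique, unknown or untested is made for them only; others in the source may bear on it.

Measured so far:
compound 1 `Oc1cccc(-c2cc(-c3ccccc3F)cc(-c3cccc(O)c3)n2)c1` — 4370 nM
compound 2 `Oc1ccc(-c2cc(-c3ccccc3F)cc(-c3cccc(O)c3)n2)cc1` — 6370 nM
compound 3 `Oc1ccc(-c2cc(-c3ccccc3OC(F)(F)F)cc(-c3cccc(O)c3)n2)cc1` — 7300 nM

Of the compounds shown here, three have been tested in a functional assay on T47D cells (Homo sapiens) for inhibition; on this read-out lower numbers stand for stronger inhibition and higher numbers for weaker inhibition. In this assay compound 1 gives 4370 nM. Compound 2 differs from compound 1 in one place: 4-hydroxyphenyl in place of 3-hydroxyphenyl on an aromatic carbon. That step produced a 1.5-fold higher number from compound 1 to compound 2 (0.16 log units; within the scatter). Compound 3 carries a further change, and moving from compound 2 to compound 3 produced a 1.1-fold higher number from compound 2 to compound 3 (0.06 log units; within the scatter). All three numbers thus sit within the usual scatter of one another, and none of the compounds can be set apart as stronger or weaker on this evidence.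

Compound 4 `Oc1ccc(-c2cc(-c3ccccc3OC(F)(F)F)cc(-c3ccc(O)cc3)n2)cc1` has not yet been measured. It differs from compound 3 in one place: 4-hydroxyphenyl in place of 3-hydroxyphenyl on an aromatic carbon. Going by the values given here, this is the same kind of change as the one from compound 1 to compound 2, though the surroundings differ: in the earlier pair the place was meta to a 2-fluorophenyl group and meta to a 3-hydroxyphenyl group, whereas here it is meta to a 4-hydroxyphenyl group and meta to a large group. The difference between the two cores, that of compound 1 and that of compound 3, is not broken down here.

Given that the same kind of change from compound 1 to compound 2 gave a 1.5-fold higher number from compound 1 to compound 2 (0.16 log units; within the scatter), the corresponding step is expected to come out as a 1.3-fold higher number from compound 3 to compound 4 (0.11 log units; within the scatter). Compound 4 is therefore estimated at 9500 nM, with a likely range from 4500 nM to 20000 nM.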

Compound 4, half-maximal inhibitory concentration: 9840 nM
For compound 4 the middle estimate is 1.0-fold (0.02 log units) below the measured one, within the range that was stated.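

In this assay, putting 4-hydroxyphenyl in place of 3-hydroxyphenyl on the core of compound 3 gave a 1.3-fold higher number from compound 3 to compound 4 (0.13 log units; within the scatter). The same change thus reads alike on the two cores, one carrying a 2-fluorophenyl group and the other a trifluoromethoxy-bearing phenyl group: the same change on two cores in this assay, a 1.5-fold higher number (0.16 log units; within the scatter) from compound 1 to compound 2 and a 1.3-fold higher number (0.13 log units; within the scatter) from compound 3 to compound 4, 1.1-fold (0.03 log units) apart, within the scatter of two such steps. This shows that the step stayed within the scatter in both pairs, but it does not show that the change does anything measurable on either core, as steps of this size cannot separate a small shift from none, and two pairs say nothing about how the change would read on a core outside this set.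

The compounds shown leave open whether a group other than the hydroxyl on these phenyl rings, such as an amine or a carboxylic acid, would take the number beyond the scatter, and whether the same swap would still read alike with a methyl group or a longer chain in place of the fluoro or trifluoromethoxy group. They also leave open how this change would read in any test other than this assay.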